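Swapping the sulfur linker for an amine linker

A few compounds are considered here, and "the series" means these few. Any claim that something is new, unique, unknown or untested is made for them only; others in the source may bear on it.

Among the measured compounds shown here, compound 2 `COc1cccc(Oc2c(NS(=O)(=O)c3ccc(C(C)(C)C)cc3)ncnc2SCCOc2ncccn2)c1` gives 25.8 nM in an assay on cells (Endothelial cell) for binding affinity to Endothelin-1 receptor (Sus scrofa) (a higher number here means a weaker inhibitor, a lower number a stronger inhibitor), the higher of the two numbers measured so far; compound 1 `COc1cccc(Oc2c(NS(=O)(=O)c3ccc(C(C)(C)C)cc3)ncnc2OCCOc2ccncn2)c1` gives 1.2 nM. Compound 3 `COc1cccc(Oc2c(NCCOc3ncccn3)ncnc2NS(=O)(=O)c2ccc(C(C)(C)C)cc2)c1` differs from compound 2 by (2-((pyrimidin-2-yl)oxy)ethyl)amino in place of (2-((pyrimidin-2-yl)oxy)ethyl)sulfanyl on an aromatic carbon. For the measured compounds named here, only one measured step exists, a 22-fold higher number from compound 1 to compound 2 (1.33 log units; beyond the scatter), and it changes both the linker atom and the pyrimidine attachment at once, so it bears on the new change only loosely. A moderate step downward is expected, a 3.2-fold lower number from compound 2 to compound 3 (0.51 log units; beyond the scatter), since the oxygen-linked compound 1 was far stronger. Compound 3 is estimated at 8 nM, with a range from 2 nM to 40 nM.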

Compound 3, half-maximal inhibitory concentration: 6.2 nM
Estimate against measurement, compound 3: 1.3-fold (0.11 log units) above; low and high end bracket the measured number.
By their numbers in this assay, from the lowest: compound 1; then compound 3; then compound 2.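

In this assay the amino linker gives a 4.2-fold lower number from compound 2 to compound 3 (0.62 log units; beyond the scatter) with the pyrimidin-2-yl ether held constant, so the linking atom matters on its own at this position. The earlier step could not show this, as it changed the linking atom and the pyrimidine attachment together. The amino linker still gives a 5.2-fold higher number from compound 1 to compound 3 (0.71 log units; beyond the scatter) in a step that also changes both features, so it does not isolate either one. No measured evidence explains these steps. Still open, as far as these compounds go, is how a methylamino linker or a longer chain would compare here.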